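From 4-cyanobenzyl to 2-cyanobenzyl

The source may hold more compounds than are shown below. What is called first, only, known or untested is meant among the compounds shown, and "the series" means these compounds.

In a functional assay on A-375 cells (Homo sapiens) for antiproliferative activity, read by MTT assay, with a stated time of 24 h (a lower number here means a stronger inhibitor, a higher number a weaker inhibitor), compound 1 `COc1cc(OC)c(-c2coc3cc(OCC(=O)c4cccc(C(F)(F)F)c4)ccc3c2=O)cc1OC` gives > 10000 nM, which is a limit of the assay and not a number. Compound 2 `COc1cc(OC)c(-c2coc3cc(OCc4ccc(Br)cc4)ccc3c2=O)cc1OC` gives 1000 nM, and compound 3 `COc1cc(OC)c(-c2coc3cc(OCc4ccc(C#N)cc4)ccc3c2=O)cc1OC` gives 1550 nM. These two numbers sit close together: a 1.6-fold higher number from compound 2 to compound 3 (0.19 log units; within the scatter). Compound 4 `COc1cc(OC)c(-c2coc3cc(OCc4ccccc4C#N)ccc3c2=O)cc1OC` carries 2-cyanophenyl in place of 4-cyanophenyl on a saturated chain carbon bound to an oxygen on an aromatic ring, with 2-cyanophenyl in place of 4-cyanophenyl. Among the measured compounds shown here, no measured step moves the cyano group. The larger steps, an at least 10-fold lower number from compound 1 to compound 2 (1.00 log units; beyond the scatter) and an at least 6.4-fold lower number from compound 1 to compound 3 (0.80 log units; beyond the scatter), replace a different group, so they say little here. The closest guide is the cyano for bromo exchange in compound 3, a 1.6-fold higher number from compound 2 to compound 3 (0.19 log units; within the scatter). The expected step is therefore small, a 1.2-fold higher number from compound 3 to compound 4 (0.06 log units; within the scatter), nothing beyond the scatter. Compound 4 is estimated at 1800 nM, within a range of 700 nM to 5000 nM.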

Compound 4, half-maximal inhibitory concentration: 990 nM
Compound 4: the middle estimate sits 1.8-fold (0.26 log units) above what was measured, and the stated range covers the measured number.
By their numbers in this assay, from the lowest: compounds 4, 2 and 3 (each within the scatter of the next). At a limit, above all of these: compound 1.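

Moving the nitrile, from 4-cyanophenyl to 2-cyanophenyl, leaves the two compounds indistinguishable in this assay: a 1.6-fold lower number from compound 3 to compound 4 (0.19 log units; within the scatter). Compound 4 also cannot be told apart from the bromo compound, with a 1.0-fold lower number from compound 2 to compound 4 (0.00 log units; within the scatter), so these three compounds show no preference for one substituent or placement on this ring. The step of an at least 10-fold lower number from compound 1 to compound 4 (1.00 log units; beyond the scatter) is beyond the scatter, but it rests on a limit of the assay for compound 1: the limit of > 10000 nM in this assay, at which 1 of the 4 values shown sits.

As far as these compounds go, it remains open whether the carbonyl or the trifluoromethyl group separates compound 1 from the others. From the compounds shown here alone, how an amine or a carboxylic acid on this ring, or a longer chain to it, would read also remains open.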